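The source may report more compounds than this note shows. Statements on the series, on what has been measured and on what is new or still open speak of the compounds shown alone.

Measured compounds in a functional assay on Raji cells (Homo sapiens) for antiproliferative activity, read by CCK-8 assay, with a stated time of 48 h; a lower number here means a stronger inhibitor, a higher number a weaker inhibitor:
compound 1 `C=CC(=O)Nc1cccc(-n2cnc3cnc(Nc4ccc(N5CCN(C(C)=O)C(C)C5)cc4)nc32)c1` gives 24200 nM
compound 2 `C=CC(=O)Nc1cccc(-n2cnc3cnc(Nc4ccc(N5CCN(S(C)(=O)=O)CC5)cc4OC)nc32)c1` gives 21900 nM
compound 3 `C=CC(=O)Nc1cccc(-n2cnc3cnc(Nc4ccc(N5CCN(S(C)(=O)=O)C(C)C5)cc4)nc32)c1` gives 31700 nM

Among these three numbers compound 2 has the smallest, yet its gap to compound 1 and its gap to compound 3 both lie within the scatter, so the three compounds are not separated from one another. Within the data shown here, the only step between compounds that differ in one place, a 1.3-fold higher number from compound 1 to compound 3 (0.12 log units; within the scatter), is likewise within the scatter.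

Compound 4 `C=CC(=O)Nc1cccc(-n2cnc3cnc(Nc4ccc(N5CCN(C)CC5)cc4OC)nc32)c1` is derived from compound 2 by methyl in place of methylsulfonyl on an amine nitrogen in a ring. Among the measured compounds shown here, no measured pair exchanges methylsulfonyl for methyl; the nearest guide is the exchange of acetyl for methylsulfonyl on the same ring nitrogen, which produced no shift beyond the scatter. With all three numbers crowded together and that one step being flat, the expectation for compound 4 is a number close to that of compound 2. The step that this estimate means, a 1.1-fold lower number from compound 2 to compound 4 (0.04 log units; within the scatter), is expected to stay within the scatter. Compound 4 is therefore estimated at 20000 nM, with a range from 8000 nM to 50000 nM.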

Compound 4, half-maximal inhibitory concentration: 13700 nM
For compound 4 the middle estimate is 1.5-fold (0.16 log units) above the measured one; the range from low to high includes it.
By their numbers in this assay, from the lowest: compounds 4, 2, 1 and 3 (each within the scatter of the next, the first and the last beyond it).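

In this assay, the methyl for methylsulfonyl exchange on the amine nitrogen in the ring gives a 1.6-fold lower number from compound 2 to compound 4 (0.20 log units; within the scatter). Until compound 4, this nitrogen had carried only acetyl or methylsulfonyl, so the result extends the flat picture to a much smaller group: a 4-(methylsulfonyl)piperazin-1-yl becomes a 4-methylpiperazin-1-yl, with four heavy atoms and two hydrogen-bond acceptors replaced by one carbon, and the two compounds remain unseparated. No measurement is available that bears on why this exchange leaves the number within the scatter. The compounds shown leave open whether a plain hydrogen on this nitrogen, or a longer chain such as hydroxyethyl or one ending in a carboxylic acid, would separate from compound 2. They also leave open whether any group at this position can move the number beyond the scatter.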